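A few compounds are considered here, and "the series" means these few. Any claim that something is new, unique, unknown or untested is made for them only; others in the source may bear on it.

Measured compounds:
- compound 1 `Cc1cccc(CSc2cc(Cl)c(C)cc2S(=O)(=O)/N=C(\N)N/N=C/C#Cc2ccccc2)c1`: in a functional assay on HCT-116 cells (Homo sapiens) for antiproliferative activity, read by MTT assay, with a stated time of 72 h (a lower number here means a stronger inhibitor, a higher number a weaker inhibitor), compound 1 gives 18000 nM
- compound 2 `Cc1cc(S(=O)(=O)/N=C(\N)N/N=C/C#Cc2ccccc2)c(SCc2ccccc2C(F)(F)F)cc1Cl`: in this assay compound 2 gives 18000 nM
- compound 3 `C/C(C#Cc1ccccc1)=N\N/C(N)=N/S(=O)(=O)c1cc(C)c(Cl)cc1SCc1ccccc1C(F)(F)F`: in this assay compound 3 gives 23000 nM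

Compound 2 stands level with compound 1, and its gap to compound 3, a 1.3-fold higher number from compound 2 to compound 3 (0.11 log units; within the scatter), is within the scatter. Compound 4 `Cc1cc(S(=O)(=O)/N=C(\N)N/N=C/C#Cc2ccccc2)c(SCc2ccc(Cl)cc2)cc1Cl` differs from compound 2 by 4-chlorophenyl in place of 2-(trifluoromethyl)phenyl on a saturated chain carbon bound to a sulfur. For the measured compounds named here, the one measured step at this same place, no change at the digits printed from compound 1 to compound 2 (within the scatter), stayed flat, and the other step, on the amine nitrogen, also stayed within the scatter. Going by the values given here, no measured step at the sulfur-bound carbon has moved the number, so compound 4 is expected to show no shift beyond the scatter, no change at the digits printed from compound 2 to compound 4 (within the scatter). Compound 4 is therefore estimated at 18000 nM, with a range from 9000 nM to 36000 nM.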

Compound 4, half-maximal inhibitory concentration: 8000 nM
Beside the measured number, compound 4's estimate is 2.3-fold (0.35 log units) above it; measured number outside the range, below it.
By their numbers in this assay, from the lowest: compound 4; then compounds 1, 2 and 3 (each within the scatter of the next).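

In this assay the change to 4-chlorophenyl gives a 2.3-fold lower number from compound 2 to compound 4 (0.35 log units; beyond the scatter) and a 2.3-fold lower number from compound 1 to compound 4 (0.35 log units; beyond the scatter) and so shows that the group on the saturated chain carbon bound to a sulfur can move the number, modestly, beyond the scatter. The 2-(trifluoromethyl)phenyl and 3-methylphenyl groups had not separated at this place, whereas 4-chlorophenyl stands apart from both. No evidence is available that accounts for this shift.

Each step changes the ring substituent and where it sits together, so those two changes remain unseparated. As far as these compounds go, whether an unsubstituted phenyl, a 4-methoxyphenyl or a longer chain to the ring would lower the number further remains open.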